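The source may report more compounds than this note shows. Statements on the series, on what has been measured and on what is new or still open speak of the compounds shown alone.

Measured compounds:
Compound 1 `CCCCC(OC)c1cccc(NC(=O)CCl)c1` gives 12000 nM in a functional assay on MCF7 cells (Homo sapiens) for antiproliferative activity, with a stated time of 48 h; on this read-out lower numbers stand for stronger inhibition and higher numbers for weaker inhibition.
Compound 2 `CCCCC(O)c1cccc(NC(=O)CCCCl)c1` gives > 100000 nM in this assay, which is a limit of the assay and not a number.

Compound 2 thus stands at the assay's limit, the point described in the limit of > 100000 nM in this assay, at which 1 of the 2 values shown sits. Compound 3 `CCCCC(OC)c1cccc(NC(=O)CCCCl)c1` differs from compound 2 by methyl in place of hydrogen on an oxygen on a saturated carbon. Among the compounds with values here, no measured step separates these two compounds. Compound 1 carries the same methoxy but a different amide chain, and it shows only a weak value. The step of an at least 1.2-fold lower number from compound 2 to compound 3 (0.09 log units; that floor lies within the scatter) is expected to be small, with no clear direction beyond the scatter. Compound 3 is expected near 80000 nM, between 20000 nM and 300000 nM.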

Compound 3, half-maximal inhibitory concentration: > 100000 nM
Compound 3 ended at the assay's limit; the forecaster's own chance of this, stated with the estimate: 55%; middle value at least 1.2-fold (0.09 log units) away from the limit.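

In this assay, with the methoxy held fixed, 2-chloroethyl in place of chloro on a saturated chain carbon bound to a carbonyl carbon gives an at least 8.3-fold higher number from compound 1 to compound 3 (0.92 log units; beyond the scatter), so this change on the amide chain costs activity beyond the scatter. The hydroxy to methoxy change cannot be read on this chain, as the values of compound 2 and compound 3 are both limits and not numbers: the limit of > 100000 nM in this assay, at which 2 of the 3 values shown sit.

From the compounds shown here alone, what the hydroxy to methoxy change does on the amide chain of compound 1 stays open. So does what an amine would give in place of the methoxy.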